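Series notes: thioether chain change from compound 2 to compound 4

The compounds below may be only part of what the source reports. "The series", "measured", "known", "first", "only" and "open" are said of these compounds alone.

In a functional assay on PC-9 cells (Homo sapiens) for inhibition, read by MTT assay, with a stated time of 72 h (on this read-out lower numbers stand for stronger inhibition and higher numbers for weaker inhibition), compound 2 `Cc1cc(Nc2cc(-c3ccccc3)[nH]n2)n2nc(SCc3ccc(Cl)cc3)nc2n1` gives 6710 nM, the highest of the two numbers obtained. Compound 3 `Cc1cc(Nc2cc(-c3ccc(F)cc3)[nH]n2)n2nc(SCc3ccc(Br)cc3)nc2n1` gives 6210 nM, within the scatter of compound 2. Compound 1 `CCCCCc1c(C)nc2nc(SCc3ccc(Cl)cc3)nn2c1Nc1cc(-c2ccccc2)[nH]n1` reports only a limit, > 50000 nM, as noted in the limit of > 50000 nM in this assay, at which 1 of the 3 values shown sits. Within the data shown here, the one measured step, an at least 7.4-fold lower number from compound 1 to compound 2 (0.87 log units; beyond the scatter), concerns hydrogen in place of pentyl on an aromatic carbon and does not touch the sulfur-bound chain. Compound 4 `CCCSc1nc2nc(C)cc(Nc3cc(-c4ccccc4)[nH]n3)n2n1` differs from compound 2 by ethyl in place of 4-chlorophenyl on a saturated chain carbon bound to a sulfur. Among the measured compounds shown here, no measured step bears on this change, so the direction is open; a weaker number is thought somewhat more likely. Compound 4 is expected near 15000 nM, with a range of 4000 nM to 50000 nM. The estimated step is a 2.2-fold higher number from compound 2 to compound 4 (0.35 log units; beyond the scatter).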

Compound 4, half-maximal inhibitory concentration: > 50000 nM
Compound 4: only a limit was reported; the forecaster's own chance of this, stated with the estimate: 25%; middle value at least 3.3-fold (0.52 log units) from the limit.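

Going from (4-chlorobenzyl)sulfanyl to propylsulfanyl is the first change seen on the sulfur-bound chain, and in this assay it gives an at least 7.4-fold higher number from compound 2 to compound 4 (0.87 log units; beyond the scatter). This position is therefore not indifferent to the change, which the earlier step, confined to the pentyl, could not show. Compound 4 reports > 50000 nM, which is a limit and not a number: the limit of > 50000 nM in this assay, at which 2 of the 4 values shown sit.

On these data alone, whether the loss follows from removing the 4-chlorophenyl or from shortening the chain stays open. A longer chain such as hexyl, or a benzyl bearing an amine, would help separate the two.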